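Chloro in Place of Hydrogen on the Aryl Ring

The compounds below may be only part of what the source reports. "The series", "measured", "known", "first", "only" and "open" are said of these compounds alone.

Compound 1, `CC1=CSC(O)(c2cccc(C(F)(F)F)c2)c2noc(=O)n21`, gives 71000 nM in a functional assay on A2780/DX3 cells (Homo sapiens) for antiproliferative activity, read by MTT assay, with a stated time of 3 days; a lower number here means a stronger inhibitor, a higher number a weaker inhibitor.
Compound 2, `CC1=CSC(O)(c2ccccc2)c2noc(=O)n21`, reaches only a limit of the assay, > 100000 nM, in this assay.

Compound 2 therefore stands at the weak end of what has been measured, and only a limit is known for it; this is where the limit of > 100000 nM in this assay, at which 1 of the 2 values shown sits, applies. Compound 3, `CC1=CSC(O)(c2cccc(Cl)c2)c2noc(=O)n21`, differs from compound 2 by chloro in place of hydrogen on an aromatic carbon. Within the data shown here, the one measured step that bears on this position is an at least 1.4-fold higher number from compound 1 to compound 2 (0.14 log units; that floor lies within the scatter), which introduces hydrogen where a trifluoromethyl stood and lies at a floor within the scatter. Read in reverse, putting a substituent back at that place would be expected to give at most a modest move toward a lower number in this assay, and the step is estimated as an at least 1.2-fold lower number from compound 2 to compound 3 (0.09 log units; that floor lies within the scatter). Compound 3 is accordingly expected to give about 80000 nM, with a range from 30000 nM to 200000 nM, and a real chance that again only a limit is recorded.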

Compound 3, half-maximal inhibitory concentration: > 100000 nM
Compound 3: only a limit was reported (the forecaster's own chance of this, stated with the estimate: 40%); at least 1.2-fold (0.09 log units) between middle value and limit.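

With chloro at this place, compound 3 joins compound 2 at a limit of the assay, so the step between them cannot be read, and a limit is now the most common result among the compounds shown: the limit of > 100000 nM in this assay, at which 2 of the 3 values shown sit.

Chloro in place of trifluoromethyl gives an at least 1.4-fold higher number from compound 1 to compound 3 (0.14 log units; that floor lies within the scatter), so this floor does not separate the two groups by more than the scatter. In this assay, among these compounds, compound 1, at 71000 nM, remains the only one of the three compounds with a number rather than a limit.

The compounds shown leave open whether another group at this place, such as a methoxy group, an amine or a carboxylic acid, would move the result well clear of the limit. Also open, from the compounds shown here alone, is how far compound 2 and compound 3 lie beyond their limits, and whether a longer chain in place of the methyl on the shared core would change the result.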